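Methoxy to Nitro: From Compound 2 to Compound 3

This account rests on a few compounds, and the source may have more. Where it says the series, first, only, none or still open, it means among the compounds named here.

Compound 2 `CCc1c(Cc2c(Cl)cccc2Cl)nc(SCc2ccc(OC)cc2)[nH]c1=O` has been tested in an ADME assay on MT4 cells (Homo sapiens) for cytotoxicity, read by MTT assay; a lower number here means that less compound is tolerated, a higher number that more compound is tolerated. For compound 2 the result is a limit of the assay, > 287000 nM. Where compound 2 stands is given by the limit of > 287000 nM in this assay, at which 1 of the 2 values shown sits. Compound 1 `CCc1c(Cc2cccc(Br)c2)nc(SCc2ccc([N+](=O)[O-])cc2)[nH]c1=O`, which also carries a nitro group, gives 187000 nM in this assay. Compound 3 `CCc1c(Cc2c(Cl)cccc2Cl)nc(SCc2ccc([N+](=O)[O-])cc2)[nH]c1=O` awaits measurement. It differs from compound 2 by nitro in place of methoxy on an aromatic carbon. Within the data shown here, no measured step covers this change, so the expected step is small, near the scatter, an at least 1.4-fold lower number from compound 2 to compound 3 (0.15 log units; that floor lies within the scatter). Compound 3 is thus estimated at 200000 nM in this assay, within a range from 100000 nM to 300000 nM.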

Compound 3, half-maximal cytotoxic concentration: > 278000 nM
Compound 3: only a limit was reported (the forecaster's own chance of this, stated with the estimate: 40%); middle value at least 1.3-fold (0.14 log units) away from the limit.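

In this assay compound 3 also ends at a limit of the assay, > 278000 nM. Compound 2 stands at a limit as well, and the step of nitro in place of methoxy cannot be read. Setting 2,6-dichlorophenyl in place of 3-bromophenyl gives an at least 1.4-fold higher number from compound 1 to compound 3 (0.17 log units; that floor lies within the scatter).

As far as these compounds go, it remains open whether any group on this aromatic carbon, such as an amine or a carboxylic acid, would give a number rather than a limit with 2,6-dichlorophenyl in place. Also open, from the compounds shown here alone, is how methoxy would read alongside 3-bromophenyl.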